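The source may hold more compounds than are shown below. What is called first, only, known or untested is meant among the compounds shown, and "the series" means these compounds.

Measured compounds:
Compound 1 `Cc1cn([C@H]2C[C@H](SSC(Cl)(Cl)Cl)[C@@H](CO)O2)c(=O)[nH]c1=O`: 55000 nM
Compound 2 `Cc1cn([C@H]2C[C@H](SSc3ccc([N+](=O)[O-])cc3)[C@@H](CO)O2)c(=O)[nH]c1=O`: 29000 nM

In a functional assay on MOLT-4 cells (Homo sapiens) for cytotoxicity (a higher number here means a weaker inhibitor, a lower number a stronger inhibitor), compound 1 gives 55000 nM and stands at the higher of the two numbers in hand. Among the compounds with values here, its only neighbour is compound 2, which in this assay gives 29000 nM; the two are separated by a 1.9-fold lower number from compound 1 to compound 2 (0.28 log units; within the scatter), so no order between them can be claimed.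

The unmeasured compound 3 `CCCCCCCCSS[C@H]1C[C@H](n2cc(C)c(=O)[nH]c2=O)O[C@@H]1CO` shares the core of compound 1 and differs from it at the disulfide position: octyl in place of trichloromethyl on a sulfur. Within the data shown here, the single measured step at that same sulfur, a 1.9-fold lower number from compound 1 to compound 2 (0.28 log units; within the scatter), exchanged trichloromethyl for 4-nitrophenyl and did not move the number beyond the scatter. Among the measured compounds shown here, no measured compound carries octyl, or any other chain, at this position, so the data offer no direction for the new group. For the measured compounds named here, on that basis the step to compound 3 in this assay is expected to be small, a 1.4-fold lower number from compound 1 to compound 3 (0.14 log units; within the scatter), with a wide range because the one relevant step is only a 1.9-fold lower number from compound 1 to compound 2 (0.28 log units; within the scatter). Compound 3 is estimated to give 40000 nM, with a range from 10000 nM to 120000 nM.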

Compound 3, half-maximal inhibitory concentration: 26000 nM
Compound 3: the middle estimate sits 1.5-fold (0.19 log units) above what was measured; the range from low to high includes it.
By their numbers in this assay, from the lowest: compounds 3, 2 and 1 (each within the scatter of the next, the first and the last beyond it).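

In this assay, within the data shown here, the change from trichloromethyl to octyl on a sulfur whose other neighbour is sulfur gives the first step at this position to pass the scatter, a 2.1-fold lower number from compound 1 to compound 3 (0.33 log units; beyond the scatter), although the step is only modest. The same change shows that this position accepts an unbranched carbon chain without any loss in this read-out, and the chain cannot be told apart from the aromatic substituent of the earlier pair, as the step of a 1.1-fold lower number from compound 2 to compound 3 (0.05 log units; within the scatter) stays within the scatter. Nothing available here accounts for the shift away from trichloromethyl.

With one chain in hand, the compounds shown leave open whether length matters at all, since neither a shorter chain such as butyl nor a longer one such as dodecyl appears among them. They also leave open how a chain ending in an amine or a carboxylic acid would behave on this sulfur, and whether any group here can take the number well beyond the narrow span these three compounds occupy.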